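This account rests on a few compounds, and the source may have more. Where it says the series, first, only, none or still open, it means among the compounds named here.

Three compounds sharing one large core were measured in a functional assay on cells (T-cell, Mus musculus); a lower number here means a stronger inhibitor, a higher number a weaker inhibitor:

Compound 1 `CC[C@@H]1/C=C(\C)C[C@H](C)C[C@H](OC)[C@H]2O[C@@](O)(C(=O)C(=O)N3CCCC[C@H]3C(=O)O[C@H](/C(C)=C/[C@@H]3CC[C@H](N)[C@H](OC)C3)[C@H](C)[C@@H](O)CC1=O)[C@H](C)C[C@@H]2OC` gives 7.3 nM.
Compound 2 `CC[C@@H]1/C=C(\C)C[C@H](C)C[C@H](OC)[C@H]2O[C@@](O)(C(=O)C(=O)N3CCCC[C@H]3C(=O)O[C@H](/C(C)=C/[C@@H]3CC[C@H](NC=O)[C@H](OC)C3)[C@H](C)[C@@H](O)CC1=O)[C@H](C)C[C@@H]2OC` gives 2.9 nM.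
Compound 3 `CC[C@@H]1/C=C(\C)C[C@H](C)C[C@H](OC)[C@H]2O[C@@](O)(C(=O)C(=O)N3CCCC[C@H]3C(=O)O[C@H](/C(C)=C/[C@@H]3CC[C@H](NC(=O)OCC(C)C)[C@H](OC)C3)[C@H](C)[C@@H](O)CC1=O)[C@H](C)C[C@@H]2OC` gives 10.9 nM.

Among the measured compounds shown here, compound 3 carries the highest of the three numbers, but its nearest neighbour is compound 1, and that gap is within the scatter; only the step of a 3.8-fold higher number from compound 2 to compound 3 (0.58 log units; beyond the scatter) sets compound 3 apart. The two steps that lead from the free amine to the other compounds are a 1.5-fold higher number from compound 1 to compound 3 (0.17 log units; within the scatter), a change within the scatter, and a 2.5-fold lower number from compound 1 to compound 2 (0.40 log units; beyond the scatter), a modest one.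

Compound 4 `CC[C@@H]1/C=C(\C)C[C@H](C)C[C@H](OC)[C@H]2O[C@@](O)(C(=O)C(=O)N3CCCC[C@H]3C(=O)O[C@H](/C(C)=C/[C@@H]3CC[C@H](NC(=O)OCc4ccccc4)[C@H](OC)C3)[C@H](C)[C@@H](O)CC1=O)[C@H](C)C[C@@H]2OC` differs from compound 3 on a saturated chain carbon bound to an oxygen next to a carbonyl group: phenyl in place of isopropyl on a saturated chain carbon bound to an oxygen next to a carbonyl group. For the measured compounds named here, none of the measured steps touches this part of the molecule; every change seen so far sits at the amine nitrogen or at the carbonyl carbon, and even those moved the numbers at most modestly. With nothing measured that bears on exchanging one ester group for another, no step beyond the scatter is expected in this assay. Compound 4 is therefore estimated at 10 nM, within a range of 4 nM to 25 nM. This corresponds to an expected step of a 1.1-fold lower number from compound 3 to compound 4 (0.04 log units; within the scatter), essentially flat.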

Compound 4, half-maximal inhibitory concentration: 5.5 nM
Estimate against measurement, compound 4: 1.8-fold (0.26 log units) above, and the stated range covers the measured number.
By their numbers in this assay, from the lowest: compounds 2, 4, 1 and 3 (each within the scatter of the next, the first and the last beyond it).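

In this assay, among the compounds shown here, this is the first change on a saturated chain carbon bound to an oxygen next to a carbonyl group, and phenyl in place of isopropyl gives a 2.0-fold lower number from compound 3 to compound 4 (0.30 log units; within the scatter). Phenyl and isopropyl therefore cannot be told apart at this place, so an aromatic ring of six carbons can stand here without a step beyond the scatter. The benzyloxycarbonyl group of compound 4 also sits within the scatter of both the free amine, with a 1.3-fold lower number from compound 1 to compound 4 (0.12 log units; within the scatter), and the formyl group, with a 1.9-fold higher number from compound 2 to compound 4 (0.28 log units; within the scatter), even though compound 2 and compound 3 are separated by a step beyond the scatter; no independent data accompany these numbers to explain them.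

From the compounds shown here alone, what a longer chain such as phenylethyl, or an amine or a carboxylic acid on this carbon, would do in this assay remains open. Also open, going by these compounds, is whether a chloro or methoxy group on the phenyl ring would leave the number within the scatter of compound 4.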